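Extending the chain toward the phenyl ring in a thiophene-fused amine series

The compounds below may be only part of what the source reports. "The series", "measured", "known", "first", "only" and "open" are said of these compounds alone.

Among the compounds with values here, compound 3 `CCN(CCCc1ccccc1)C1CCc2ccsc2CC1` gives 33 nM in an assay on membranes from liver for displacement of a labelled ligand from Sigma intracellular receptor 2 (Rattus norvegicus), read by scintillation counting, with a stated time of 120 min, in the presence of a further agent that is not named here (on this read-out higher numbers stand for weaker inhibition and lower numbers for stronger inhibition), the highest of the three numbers measured so far. Compound 2 `CN(CCCCc1ccccc1)C1CCc2ccsc2CC1` gives 12 nM, and compound 1 `c1ccc(CCCCNC2CCc3ccsc3CC2)cc1` gives 5.7 nM. Within the data shown here, the one step measured between neighbours, a 2.1-fold higher number from compound 1 to compound 2 (0.32 log units; beyond the scatter), shows a modest loss on adding a methyl to the amine nitrogen.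

Compound 4 `CCN(CCCCc1ccccc1)C1CCc2ccsc2CC1` has not yet been measured. It differs from compound 3 in one place: benzyl in place of phenyl on a saturated chain carbon, three bonds along the chain from an amine nitrogen. Among the measured compounds shown here, no measured pair isolates this change, so there is no direct guide to its size or direction. Compound 4 is, however, compound 2 with an ethyl rather than a methyl on the amine nitrogen, and compound 2 gives 12 nM, a lower number than compound 3. Taking the modest loss seen for a 2.1-fold higher number from compound 1 to compound 2 (0.32 log units; beyond the scatter) as a hint that a larger group on the nitrogen costs a little, compound 4 is expected to land between compound 2 and compound 3 in this assay. The estimate for compound 4 is 18 nM, with a range of 6 nM to 50 nM, which means an expected step of a 1.8-fold lower number from compound 3 to compound 4 (0.26 log units; within the scatter).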

Compound 4, inhibition constant: 46 nM
For compound 4 the middle estimate is 2.6-fold (0.41 log units) below the measured one; low and high end bracket the measured number.
By their numbers in this assay, from the lowest: compound 1; then compound 2; then compounds 3 and 4 (each within the scatter of the next).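

With ethyl on the amine nitrogen, benzyl in place of phenyl gives a 1.4-fold higher number from compound 3 to compound 4 (0.14 log units; within the scatter) in this assay and so has no effect that can be told from the scatter. The group on the nitrogen shows a clearer trend with the chain of compound 1 held fixed: ethyl in place of methyl gives a 3.8-fold higher number from compound 2 to compound 4 (0.58 log units; beyond the scatter) and ethyl in place of hydrogen gives an 8.1-fold higher number from compound 1 to compound 4 (0.91 log units; beyond the scatter), so the number climbs from hydrogen through methyl to ethyl across these three compounds. Nothing available explains these steps.

From the compounds shown here alone, it remains open whether a propyl group on the nitrogen would carry this climb further. Going by these compounds, it is also open whether a longer chain, or a methoxy group on the phenyl ring, would move the number beyond the scatter.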